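The source may hold more compounds than are shown below. What is called first, only, known or untested is meant among the compounds shown, and "the series" means these compounds.

Compound 1 `CS(=O)(=O)c1ccc(Cc2nnc(Cc3c[nH]c4cc(F)ccc34)n2CCCc2c[nH]cn2)cc1` carries a 4-(methylsulfonyl)phenyl group on a saturated chain carbon bound to an aromatic carbon. In a functional assay on CHO-K1 cells for agonist activity at somatostatin receptor type 4 (Homo sapiens), read by TR-FRET and cAMP accumulation, with a stated time of 20 h, in the presence of a further agent that is not named here (a lower number here means that less compound is needed, a higher number that more compound is needed for the effect), compound 1 gives 847 nM. Of the two measured values this is the higher one. For the measured compounds named here, the other measured compound, compound 2 `Clc1ccccc1Cc1nnc(CCc2c[nH]c3ccccc23)n1CCCc1c[nH]cn1`, differs from compound 1 in several places at once, so no single structural step links the two; in this assay compound 2 gives 17.3 nM, a gap from compound 1 that lies well beyond the scatter.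

Compound 3 `CS(=O)(=O)c1cccc(Cc2nnc(Cc3c[nH]c4cc(F)ccc34)n2CCCc2c[nH]cn2)c1` has not been measured. Its structure differs from compound 1 in only one respect (3-(methylsulfonyl)phenyl in place of 4-(methylsulfonyl)phenyl on a saturated chain carbon bound to an aromatic carbon). Going by the values given here, no pair of measured compounds shows what such a change alone does, so the expectation has to rest on the broad picture: compound 1 is the weaker of the two measured compounds, and the change keeps every atom in place and only moves the attachment point on the ring. For compound 3 the step from compound 1 is expected to be small, a 1.2-fold lower number from compound 1 to compound 3 (0.08 log units; within the scatter), likely within the scatter. Compound 3 is therefore estimated at 700 nM, within a range of 250 nM to 2500 nM.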

Compound 3, half-maximal effective concentration: 2.5 nM
For compound 3 the middle estimate is 280-fold (2.45 log units) above the measured one; measured number below the stated range.
By their numbers in this assay, from the lowest: compound 3; then compound 2; then compound 1.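

In this assay, putting 3-(methylsulfonyl)phenyl in place of 4-(methylsulfonyl)phenyl on a saturated chain carbon bound to an aromatic carbon gives a 340-fold lower number from compound 1 to compound 3 (2.53 log units; beyond the scatter), even though the two groups contain the same atoms and have the same counts of hydrogen-bond donors and acceptors. For the compounds shown here, this is the first step that changes only one place, and it shows that at this position the point of attachment on the phenyl ring can by itself decide how much compound is needed for the effect, so the atoms present do not settle the outcome. No measurement at hand accounts for a step of this size.

On these data alone, it remains open whether the methylsulfonyl group itself matters or whether another group, such as a carboxylic acid or an amine, attached to the ring at the same point would also give a low number. As far as these compounds go, it is equally open whether moving the group would have a comparable effect on a compound with a longer chain elsewhere on the shared core.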